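Acyl chains on a shared core and cytotoxicity

This account rests on a few compounds, and the source may have more. Where it says the series, first, only, none or still open, it means among the compounds named here.

Values in a functional assay on CCRF-CEM cells (Homo sapiens) for cytotoxicity; on this read-out higher numbers stand for lower toxicity in this test and lower numbers for higher toxicity in this test:
Compound 1 `CC(=O)Nc1nc(N)nc2c1ncn2[C@H]1CO[C@@H](CO)O1`: > 100000 nM
Compound 2 `CCCCCCCC(=O)Nc1nc(N)nc2c1ncn2[C@H]1CO[C@@H](CO)O1`: > 100000 nM
Compound 3 `CCCCCCCCCC(=O)Nc1nc(N)nc2c1ncn2[C@H]1CO[C@@H](CO)O1`: 65000 nM

Compound 2 stands at the limit of > 100000 nM in this assay, at which 2 of the 3 values shown sit, so its entry is a limit of the assay and not a number. The entry for compound 1 is a limit too. Only compound 3 gives a number in this assay, 65000 nM.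

Compound 4 `CCCCCCCC/C=C\CCCCCCCC(=O)Nc1nc(N)nc2c1ncn2[C@H]1CO[C@@H](CO)O1` has not yet been measured. It differs from compound 2 by dec-1-en-1-yl in place of hydrogen on a saturated chain carbon, seven bonds along the chain from a carbonyl carbon.

The closest measured change is an at least 1.5-fold lower number from compound 2 to compound 3 (0.18 log units; that floor lies within the scatter), with ethyl in place of hydrogen at the same place on the chain. The step of an at least 1.5-fold lower number from compound 1 to compound 3 (0.18 log units; that floor lies within the scatter) has the same floor, while the step that the two limits leave unreadable from compound 1 to compound 2 says nothing about size. These steps point only weakly towards lower numbers, so a modest move in that direction is expected, and compound 4 may well stay at the limit. The step expected is an at least 2.0-fold lower number from compound 2 to compound 4 (0.30 log units; that floor lies within the scatter). For compound 4 the estimated value is 50000 nM, with an expected range of 18000 nM to 100000 nM.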

Compound 4, half-maximal cytotoxic concentration: 13000 nM
For compound 4 the middle estimate is 3.8-fold (0.59 log units) above the measured one, and the stated range ends above it.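

In this assay, dec-1-en-1-yl at this place, seven bonds along the chain from a carbonyl carbon, gives a step clearly beyond the scatter: an at least 7.6-fold lower number from compound 2 to compound 4 (0.88 log units; beyond the scatter). That size is only a floor, as the entry for compound 2 is a limit and not a number: the limit of > 100000 nM in this assay, at which 2 of the 4 values shown sit. Among the compounds shown here, the comparison with two real numbers, a 5.0-fold lower number from compound 3 to compound 4 (0.70 log units; beyond the scatter), shows that this position can move the read-out by a readable amount, where the earlier steps gave only floors within the scatter or could not be read.

Compound 4 is the only one shown with a double bond in its chain, so the double bond and the added chain length cannot be told apart. As far as these compounds go, whether decyl at this place would give the same step, or a carboxylic acid at the chain end would keep it, remains open.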